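The compounds below may be only part of what the source reports. "The series", "measured", "known", "first", "only" and "open" are said of these compounds alone.

Compound 1 `Cc1cc(C)c(NC(=O)c2sccc2S(=O)(=O)Nc2onc(C)c2Cl)c(C)c1` gives 81600 nM
Compound 2 `COc1c(C)cc(C)c(NC(=O)c2sccc2S(=O)(=O)Nc2onc(C)c2Cl)c1C` gives 8510 nM
Compound 3 `Cc1cc(C)c(N(C)C)c(C)c1NC(=O)c1sccc1S(=O)(=O)Nc1onc(C)c1Cl` gives 6620 nM

In an in vivo ADME assay on the whole organism (plasma) for pharmacokinetics, with Rattus norvegicus as the target, at a dose of 50 mg/kg by the oral route (on this read-out lower numbers stand for lower exposure and higher numbers for higher exposure at the dose given), compound 3 shares the low end of these three numbers with compound 2, as shown by a 1.3-fold lower number from compound 2 to compound 3 (0.11 log units; within the scatter), and both lie well under compound 1. Compound 4 `Cc1cc(C)c(NC(=O)c2sccc2S(=O)(=O)Nc2onc(C)c2Cl)c(C)c1O` carries hydroxy in place of dimethylamino on an aromatic carbon, para to a methyl group and ortho to two methyl groups: hydroxy in place of dimethylamino on an aromatic carbon. Two large steps bear on this place, a 9.6-fold lower number from compound 1 to compound 2 (0.98 log units; beyond the scatter) and a 12-fold lower number from compound 1 to compound 3 (1.09 log units; beyond the scatter), and both concern a group put in place of hydrogen. Compound 4 keeps a group there, so the closest guide is the swap from methoxy to dimethylamino, a 1.3-fold lower number from compound 2 to compound 3 (0.11 log units; within the scatter), which left the number unmoved beyond the scatter. Among the compounds with values here, no measured compound carries hydroxy, so a step beyond the scatter in this assay cannot be ruled out, in either direction. The expected outcome is a 1.1-fold lower number from compound 3 to compound 4 (0.04 log units; within the scatter) and no clear shift. For compound 4 the estimate is 6000 nM, with an expected range from 1200 nM to 30000 nM.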

Compound 4, maximal plasma concentration: 106000 nM
Beside the measured number, compound 4's estimate is 18-fold (1.25 log units) below it, outside the stated range (above it).
By their numbers in this assay, from the lowest: compounds 3 and 2 (each within the scatter of the next); then compounds 1 and 4 (each within the scatter of the next).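

In this assay this position proves tolerant of a substituent as such, since a 1.3-fold higher number from compound 1 to compound 4 (0.11 log units; within the scatter), so hydroxy and hydrogen cannot be told apart here, while a 16-fold higher number from compound 3 to compound 4 (1.20 log units; beyond the scatter) and a 12-fold higher number from compound 2 to compound 4 (1.10 log units; beyond the scatter). The second of these two large steps is only hydrogen in place of methyl on the oxygen, so the low number of compound 2 goes with that one methyl and not with the oxygen on the ring itself. Nothing at hand explains why the number moves this way.

As far as these compounds go, whether a primary amine or a methylamino group at this place would stay with hydroxy and hydrogen or fall with methoxy and dimethylamino remains open. So does the effect of a longer chain on the oxygen, such as ethoxy, on the maximal plasma concentration.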